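Swapping a difluoroethyl group for a trifluoromethyl group

A few compounds are considered here, and "the series" means these few. Any claim that something is new, unique, unknown or untested is made for them only; others in the source may bear on it.

Within the data shown here, compound 1 `CC(F)(F)c1ccccc1-c1cc(C(=O)N[C@@H](CCN2CCCCC2)CC(=O)NC2CCC2)nn1C1CCCC1` is the only compound here with a number: in an ADME assay on microsomes from liver (Rattus norvegicus, strain Sprague-Dawley) for metabolic stability, read by LC-MS, using NADPH, with a stated time of 30 min, tested at 1 uM (on this read-out lower numbers stand for a less stable compound and higher numbers for a more stable compound), compound 1 gives 77.1%. Compound 2 `O=C(C[C@H](CCNC(=O)C1COC1)NC(=O)c1cc(-c2ccccc2C(F)(F)F)n(C2CCCC2)n1)NC1CCC1` was also tested in this assay, but for compound 2 the entry reads "nd" (no result reported), so no number was reported for it. Among the measured compounds shown here, compound 3 `O=C(C[C@H](CCN1CCCCC1)NC(=O)c1cc(-c2ccccc2C(F)(F)F)n(C2CCCC2)n1)NC1CCC1` differs from compound 1 in one place: fluoro in place of methyl on a saturated chain carbon bound to an aromatic carbon and two fluorine atoms No step between measured compounds is available to lean on. With compound 1 standing at 77.1%, the move is expected to stay within the usual scatter, if anything slightly upward, as a number 2.9 percentage points higher from compound 1 to compound 3 (within the scatter). Compound 3 is therefore estimated to give 80% in this assay, with a range from 65% to 92%.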

Compound 3, percent of the compound remaining: 74.6%
Compound 3: the middle estimate sits 5.4 percentage points above what was measured, within the range that was stated.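

In this assay, the change from 1,1-difluoroethyl to trifluoromethyl gives a number 2.5 percentage points lower from compound 1 to compound 3 (within the scatter). So fluoro in place of methyl on this saturated chain carbon, bound to an aromatic carbon and two fluorine atoms, leaves the two compounds indistinguishable on this read-out. Nothing available here explains this result. The compounds shown leave open how a chlorine atom, a nitrile or a methoxy group would read in place of the 1,1-difluoroethyl group, and whether any such swap would move the number beyond the usual scatter.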